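Urea aryl group changes on a shared core

This account rests on a few compounds, and the source may have more. Where it says the series, first, only, none or still open, it means among the compounds named here.

Compound 3 `CCN(CC)CCn1cnnc1-c1cc(Oc2ccc(NC(=O)Nc3ccccc3C(F)(F)F)cc2F)ccn1` gives 3410 nM in a functional assay on HT-29 cells (Homo sapiens) for antiproliferative activity, read by MTT assay, with a stated time of 72 h (on this read-out higher numbers stand for weaker inhibition and lower numbers for stronger inhibition), the highest number among the three measured compounds. Compound 1 `CCN(CC)CCn1cnnc1-c1cc(Oc2ccc(NC(=O)Nc3ccc(Cl)c(C(F)(F)F)c3)cc2F)ccn1` gives 900 nM in this assay, and compound 2 `CCN(CC)CCn1cnnc1-c1cc(Oc2ccc(NC(=O)Nc3cccc(C(F)(F)F)c3)cc2F)ccn1` gives 630 nM. For the measured compounds named here, the only steps that reach compound 3 are a 3.8-fold higher number from compound 1 to compound 3 (0.58 log units; beyond the scatter) and a 5.4-fold higher number from compound 2 to compound 3 (0.73 log units; beyond the scatter); both end at the 2-(trifluoromethyl)phenyl of compound 3 and both raise the number beyond the scatter, while the step of a 1.4-fold lower number from compound 1 to compound 2 (0.15 log units; within the scatter) stays within it.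

Compound 4 `CCN(CC)CCn1cnnc1-c1cc(Oc2ccc(NC(=O)Nc3ccc(F)c(F)c3)cc2F)ccn1` differs from compound 3 by 3,4-difluorophenyl in place of 2-(trifluoromethyl)phenyl on an amide-type nitrogen. Compound 4 therefore no longer carries the 2-(trifluoromethyl)phenyl that is present only in compound 3, the compound with the highest number. A move back toward the numbers of compound 1 and compound 2 is expected, as a lower number in this assay; the two steps into compound 3 were modest, so a modest step of a 3.4-fold lower number from compound 3 to compound 4 (0.53 log units; beyond the scatter) is expected. Going by the values given here, no measured compound carries 3,4-difluorophenyl, so the range is kept wide. Compound 4 is estimated at 1000 nM, within 350 nM to 2800 nM.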

Compound 4, half-maximal inhibitory concentration: 1240 nM
Estimate against measurement, compound 4: 1.2-fold (0.09 log units) below; low and high end bracket the measured number.
By their numbers in this assay, from the lowest: compounds 2, 1 and 4 (each within the scatter of the next); then compound 3.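

In this assay, replacing the 2-(trifluoromethyl)phenyl on the amide-type nitrogen with 3,4-difluorophenyl gives a 2.8-fold lower number from compound 3 to compound 4 (0.44 log units; beyond the scatter). The other two new steps, a 2.0-fold higher number from compound 2 to compound 4 (0.29 log units; within the scatter) and a 1.4-fold higher number from compound 1 to compound 4 (0.14 log units; within the scatter), stay within the scatter, so at this position an aryl group without trifluoromethyl matches the two trifluoromethyl-bearing aryl groups that give the lower numbers, and among the four compounds only the 2-(trifluoromethyl)phenyl stands apart. No evidence on the source of these differences is available.

As far as these compounds go, it remains open whether an unsubstituted phenyl, or an aryl group carrying an amine or a carboxylic acid, would fall in the same range at this nitrogen. For the compounds shown here, with 2-(trifluoromethyl)phenyl as the only group of its kind, it is also open whether other groups at the same ring position would raise the number as well.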